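Moving the chlorine around the indazole of compound 3

The source may hold more compounds than are shown below. What is called first, only, known or untested is meant among the compounds shown, and "the series" means these compounds.

The measured compounds:
compound 1, `CC/C(=C(/c1ccc(/C=C/C(=O)O)cc1)c1cnc2[nH]ncc2c1)c1ccccc1`, 302 nM in a functional assay on MCF7 cells (Homo sapiens) for cytotoxicity, read by CellTiter-Glo, with a stated time of 5 days; a higher number here means a weaker inhibitor, a lower number a stronger inhibitor;
compound 2, `CC/C(=C(/c1ccc(/C=C/C(=O)O)cc1)c1ccc2[nH]ncc2c1Cl)c1ccccc1`, 1.6 nM;
compound 3, `CC/C(=C(/c1ccc(/C=C/C(=O)O)cc1)c1cc2cn[nH]c2cc1Cl)c1ccccc1`, 137 nM.

Compound 3 stands second highest of the three numbers: its nearest neighbour is compound 1, as the step of a 2.2-fold lower number from compound 1 to compound 3 (0.34 log units; beyond the scatter) shows, and its furthest is compound 2, as the step of an 86-fold higher number from compound 2 to compound 3 (1.93 log units; beyond the scatter) shows.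

Compound 4, `CC/C(=C(/c1ccc(/C=C/C(=O)O)cc1)c1cc(Cl)c2[nH]ncc2c1)c1ccccc1`, has not yet been measured. It differs from compound 3 only in where the chlorine sits: 7-chloro-1H-indazol-5-yl in place of 6-chloro-1H-indazol-5-yl on a double-bonded chain carbon bound to an aromatic carbon and a double-bonded chain carbon.

Going by the values given here, no measured step repeats this exact change. The one that bears on it is the step from compound 2 to compound 3, an 86-fold higher number from compound 2 to compound 3 (1.93 log units; beyond the scatter), which shows that shifting the chlorine on the same indazole can move the number a great deal in either direction. The step of a 190-fold lower number from compound 1 to compound 2 (2.28 log units; beyond the scatter) only shows how far the scaffold of compound 2 can reach. The direction for compound 4 is therefore open; the writer expects a step of about a 2.3-fold lower number from compound 3 to compound 4 (0.36 log units; beyond the scatter), with wide uncertainty.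

Compound 4 is estimated at 60 nM in this assay, within a range from 8 nM to 400 nM.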

Compound 4, half-maximal inhibitory concentration: 56 nM
Estimate against measurement, compound 4: 1.1-fold (0.03 log units) above; measured number inside the range.
By their numbers in this assay, from the lowest: compound 2; then compound 4; then compound 3; then compound 1.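

In this assay the step of a 2.4-fold lower number from compound 3 to compound 4 (0.39 log units; beyond the scatter) shows that 7-chloro-1H-indazol-5-yl and 6-chloro-1H-indazol-5-yl are separated by a modest margin, whereas the step of a 35-fold higher number from compound 2 to compound 4 (1.54 log units; beyond the scatter) is large and leaves 4-chloro-1H-indazol-5-yl well apart from the 7-chloro group as well as the 6-chloro group. The step of a 5.4-fold lower number from compound 1 to compound 4 (0.73 log units; beyond the scatter) adds that the 7-chloro group gives a modest change from the group of compound 1, far smaller than the change to compound 2. Nothing available explains these differences.

Going by these compounds, whether a fluorine, a methyl or a nitrile in place of the chlorine of 4-chloro-1H-indazol-5-yl would keep the low number of compound 2 remains open. So does whether an amide in place of the carboxylic acid would preserve the order of these compounds.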